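Cyano in place of trifluoromethyl: notes on compound 4

A few compounds are considered here, and "the series" means these few. Any claim that something is new, unique, unknown or untested is made for them only; others in the source may bear on it.

Within the data shown here, in a functional assay on A549 cells (Homo sapiens) for inhibition, read by CCK-8 assay, with a stated time of 72 h, tested at 1 uM (a higher number here means more inhibition of growth at the concentration tested, a lower number less inhibition of growth), compound 3 `CN(C)C(=O)c1cc2cnc(Nc3ccc(NC(=O)C4(C(=O)Nc5ccc(C(F)(F)F)cc5)CC4)cc3)nc2n1C1CCCC1` gives -25.3%, the lowest of the three numbers so far. Compound 1 `CN(C)C(=O)c1cc2cnc(Nc3ccc(NC(=O)C4(C(=O)Nc5ccc(F)cc5)CC4)cc3)nc2n1C1CCCC1` gives 86.6% and compound 2 `CN(C)C(=O)c1cc2cnc(Nc3ccc(NC(=O)C4(C(=O)Nc5ccc(Br)cc5)CC4)cc3)nc2n1C1CCCC1` gives -6.6%.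

The next structure, compound 4 `CN(C)C(=O)c1cc2cnc(Nc3ccc(NC(=O)C4(C(=O)Nc5ccc(C#N)cc5)CC4)cc3)nc2n1C1CCCC1`, has cyano in place of trifluoromethyl on an aromatic carbon, para to a large group: cyano in place of trifluoromethyl on an aromatic carbon.

Among the measured compounds shown here, no measured step involves cyano, so the evidence is indirect. All three measured steps change the same place. Bromo in place of fluoro gives a number 93.2 percentage points lower from compound 1 to compound 2 (beyond the scatter), and trifluoromethyl in place of fluoro gives a number 111.9 percentage points lower from compound 1 to compound 3 (beyond the scatter). Both are large. Trifluoromethyl in place of bromo gives only a number 18.7 percentage points lower from compound 2 to compound 3 (beyond the scatter). Growth inhibition at this concentration therefore appears in compound 1 alone, and three compounds cannot show where cyano will fall between these extremes. Since compound 3 already gives -25.3%, the lowest number in the set, a move upward is more likely than a further fall, though its size is poorly constrained.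

The expected change is a number 40.3 percentage points higher from compound 3 to compound 4 (beyond the scatter). For compound 4 the estimated value in this assay is 15%, with an expected range from -25% to 75%.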

Compound 4, percent growth inhibition at one concentration: 86.1%
Compound 4: the middle estimate sits 71.1 percentage points below what was measured; the measured number lies above the stated range.
By their numbers in this assay, from the lowest: compound 3; then compound 2; then compounds 4 and 1 (each within the scatter of the next).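

In this assay growth inhibition at this position is no longer confined to fluoro: cyano in place of fluoro gives a number 0.5 percentage points lower from compound 1 to compound 4 (within the scatter) and leaves the two groups level, while cyano in place of trifluoromethyl gives a number 111.4 percentage points higher from compound 3 to compound 4 (beyond the scatter) and cyano in place of bromo gives a number 92.7 percentage points higher from compound 2 to compound 4 (beyond the scatter) in this series. The four compounds thus split into two sets, with compounds 1 and 4 high and compounds 2 and 3 low, so a change on this aromatic carbon, para to a large group, is enough to move a compound from one set to the other while the rest of the structure stays the same. Nothing available on these compounds accounts for why fluoro and cyano fall together, apart from bromo and trifluoromethyl.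

On these data alone, whether other groups on this carbon, such as chloro, methoxy, an amine or a carboxylic acid, would join the high set or the low set remains open. A reading at a single concentration also leaves open whether compounds 1 and 4 would stay level at lower concentrations, where a difference between them could still appear.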